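The source may hold more compounds than are shown below. What is called first, only, known or untested is meant among the compounds shown, and "the series" means these compounds.

For the measured compounds named here, compound 2 `CCOc1c(-c2occ(C)c2C(=O)OC)ccc2c(CC)cccc12` gives 1.8 ug/mL in a functional assay on KB cells (Homo sapiens) for cytotoxicity, read by MTT assay, with a stated time of 72 h (on this read-out lower numbers stand for an effect already at smaller amounts and higher numbers for an effect only at larger amounts of compound), and only one other plain number exists: compound 1 `CCc1cccc2c(OC)c(-c3occ(C)c3C(=O)OC)ccc12` gives 1.7 ug/mL, so that the step of a 1.1-fold higher number from compound 1 to compound 2 (0.02 log units; within the scatter) is within the scatter. Compound 3 `CCc1cccc2c(OC(C)=O)c(-c3occ(C)c3COC(C)=O)ccc12` reaches only the assay limit of > 10 ug/mL. Compound 4 `CCOc1c(-c2occ(C)c2COC)ccc2c(CC)cccc12` differs from compound 2 by methoxymethyl in place of methoxycarbonyl on an aromatic carbon. Going by the values given here, no measured step changes this group alone: the step from compound 1 to compound 2 touches a different part of the molecule, and compound 3 combines an altered ester with a second change elsewhere. Compound 3 sits at the limit of > 10 ug/mL in this assay, at which 1 of the 3 values shown sits, which leaves a weakening open. Compound 4 is therefore expected at 5 ug/mL, with a range from 1.5 ug/mL to 15 ug/mL. This amounts to an expected step of a 2.8-fold higher number from compound 2 to compound 4 (0.44 log units; beyond the scatter).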

Compound 4, concentration for half-maximal effect: > 10 ug/mL
Compound 4: no number, only a limit (the forecaster's own chance of this, stated with the estimate: 30%); middle value at least 2.0-fold (0.30 log units) from the limit.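

In this assay, putting methoxymethyl in place of methoxycarbonyl on this aromatic carbon gives an at least 5.5-fold higher number from compound 2 to compound 4 (0.74 log units; beyond the scatter). Unlike the change between compound 1 and compound 2, which stays within the scatter, this single change clearly moves the number, so the group at this position matters for the effect on these cells. Compound 4 has only a limit and not a number, so the full size of the step stays unknown: the limit of > 10 ug/mL in this assay, at which 2 of the 4 values shown sit.

The compounds shown leave open which part of the methoxycarbonyl group matters. They also leave open whether a carboxylic acid or an amide at this position would keep the value of compound 2.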